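A few compounds are considered here, and "the series" means these few. Any claim that something is new, unique, unknown or untested is made for them only; others in the source may bear on it.

Working notes on the series.

The series is read in a functional assay on EL4 cells (Mus musculus) for inhibition, tested at 100 uM; on this read-out higher numbers stand for more inhibition at the one concentration tested (going by the name of the read-out) and lower numbers for less inhibition. Compound 1 `CSc1[nH]ccc2ncnc1-2` gives only a limit of the assay rather than a number, reported as < 5%. Compound 2 `OC[C@H]1OC(n2cnc3c(Nc4ccccc4)nccc32)[C@H](O)[C@@H]1O`, which carries a sugar and an aryl amine on a larger scaffold, gives 10% in this assay. For the measured compounds named here, no pair of measured compounds differs in one place, so no measured step can be quoted; the one piece of evidence on where the values sit is the limit of < 5% in this assay, at which 1 of the 2 values shown sits, which places compound 1 at the floor of what this assay reports.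

Compound 3 `Nc1[nH]ccc2ncnc1-2` is the unmeasured member. Against compound 1 the change is amino in place of methylsulfanyl on an aromatic carbon. With compound 1 sitting at the limit, the only direction in which a number could appear is upward, and the change is a small one on the shared core, so no step beyond the usual scatter is expected. The step from compound 1 to compound 3 is estimated as a number at least 3 percentage points higher from compound 1 to compound 3 (that floor lies within the scatter). For compound 3 the expected value in this assay is 8%, with a likely range from 0% to 25%, and the estimate allows that compound 3 too may return only the limit.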

Compound 3, a percentage reported as inhibition, at one concentration (the size of the read-out at that concentration, not a potency): < 5%
Compound 3 gave a limit, no number (the forecaster's own chance of this, stated with the estimate: 50%); middle value at least 3 percentage points away from the limit.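

In this assay compound 3 gives < 5%, a limit and not a number, and compound 1 also stands at a limit, so no step between compound 1 and compound 3 can be read: the limit of < 5% in this assay, at which 2 of the 3 values shown sit.

The compounds shown leave open whether amino and methylsulfanyl on the shared core differ at all in this assay.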